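Removing the Chloro from a Pair That Sits at the Limit

A few compounds are considered here, and "the series" means these few. Any claim that something is new, unique, unknown or untested is made for them only; others in the source may bear on it.

Compound 2, `Cc1ccc(Nc2nc(C)c(C(=O)/C=C/c3ccc(Cl)cc3)s2)cc1`, is the measured neighbour of compound 3, `Cc1ccc(Nc2nc(C)c(C(=O)/C=C/c3ccccc3)s2)cc1`. In a functional assay on Bel-7402 cells (Homo sapiens) for cytotoxicity, read by MTT assay (on this read-out higher numbers stand for weaker inhibition and lower numbers for stronger inhibition), compound 2 gives > 25000 nM, a limit of the assay rather than a number. Compound 1, `Cc1nc(Nc2ccccc2)sc1C(=O)/C=C/c1ccc(Cl)cc1`, gives > 25000 nM in this assay, likewise a limit. The step that the two limits leave unreadable from compound 1 to compound 2 therefore cannot be read, and the limit of > 25000 nM in this assay, at which 2 of the 2 values shown sit, is all the shown values offer. The change to compound 3 is hydrogen in place of chloro on an aromatic carbon. With both shown values at the limit, no direction can be taken from them. Compound 3 is expected near 40000 nM, within 15000 nM to 120000 nM. The step that the limit leaves unreadable from compound 2 to compound 3 is estimated to stay within the scatter.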

Compound 3, half-maximal inhibitory concentration: > 25000 nM
Compound 3: no number, only a limit; the forecaster's own chance of this, stated with the estimate: 75%; the middle value is on the limit's open side.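

Compound 3 also gives only a limit of the assay, so no new step can be read from compound 2 to compound 3. The compounds shown leave open how strongly any of them inhibits, and so how 4-chlorophenyl and phenyl compare: the limit of > 25000 nM in this assay, at which 3 of the 3 values shown sit.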